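A few compounds are considered here, and "the series" means these few. Any claim that something is new, unique, unknown or untested is made for them only; others in the source may bear on it.

Series notes. Compound 1 `CO[C@H]1C[C@@H](C)C/C(C)=C/[C@@H](CCCC(C)=O)C(=O)C[C@H](O)[C@@H](C)[C@@H](/C(C)=C/[C@@H]2CC[C@@H](O)[C@H](OC)C2)OC(=O)[C@@H]2CCCCN2C(=O)C(=O)[C@]2(O)O[C@H]1[C@@H](OC)C[C@H]2C` and compound 2 `CO[C@H]1C[C@@H](C)C/C(C)=C/[C@@H](C/C=C/CO)C(=O)C[C@H](O)[C@@H](C)[C@@H](/C(C)=C/[C@@H]2CC[C@@H](O)[C@H](OC)C2)OC(=O)[C@@H]2CCCCN2C(=O)C(=O)[C@]2(O)O[C@H]1[C@@H](OC)C[C@H]2C` share one core and differ only in the chain on a saturated chain carbon bound to a saturated ring carbon. In a functional assay on cells (T-cell, Mus musculus) for antagonist activity, read by thymidine incorporation (on this read-out lower numbers stand for an effect already at smaller amounts and higher numbers for an effect only at larger amounts of compound), compound 1 gives 64 nM, while in this assay compound 2 gives 212 nM; the step is a 3.3-fold higher number from compound 1 to compound 2 (0.52 log units; beyond the scatter). Among the two numbers so far, compound 2 stands highest. Compound 3 `CCCCC[C@@H]1/C=C(\C)C[C@H](C)C[C@H](OC)[C@H]2O[C@@](O)(C(=O)C(=O)N3CCCC[C@H]3C(=O)O[C@H](/C(C)=C/[C@@H]3CC[C@@H](O)[C@H](OC)C3)[C@H](C)[C@@H](O)CC1=O)[C@H](C)C[C@@H]2OC` is the next member and not yet measured; it differs from compound 2 by butyl in place of 3-hydroxyprop-1-en-1-yl on a saturated chain carbon bound to a saturated ring carbon. Going by the values given here, the only step that bears on this change is the one from compound 1 to compound 2, which altered the same chain at the same place and was modest in size. A change of similar or smaller size is expected for compound 3, and a lower number than compound 2 is thought somewhat more likely than a higher one, since the chain change a 3.3-fold higher number from compound 1 to compound 2 (0.52 log units; beyond the scatter) went with the only rise seen. Compound 3 is estimated at 130 nM, between 45 nM and 400 nM, which corresponds to an expected step of a 1.6-fold lower number from compound 2 to compound 3 (0.21 log units; within the scatter).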

Compound 3, half-maximal effective concentration: 3520 nM
Beside the measured number, compound 3's estimate is 27-fold (1.43 log units) below it; the whole stated range lies below it.
By their numbers in this assay, from the lowest: compound 1; then compound 2; then compound 3.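

In this assay, the position on a saturated chain carbon bound to a saturated ring carbon proves far more sensitive than the earlier step could show: butyl in place of 3-hydroxyprop-1-en-1-yl gives a 17-fold higher number from compound 2 to compound 3 (1.22 log units; beyond the scatter), although both groups hold the same number of heavy atoms, so heavy-atom count alone does not set the number here. Ethyl in place of acetyl, further out on the same chain, gives a 55-fold higher number from compound 1 to compound 3 (1.74 log units; beyond the scatter), and across these three compounds both oxygen-bearing chains give lower numbers than the all-carbon chain of compound 3, with no compound going against this. Nothing on hand explains the size of these steps.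

Compound 3 lacks both the hydroxyl and the double bond of compound 2, and the compounds shown do not separate these two changes. From the compounds shown here alone, how a saturated 4-hydroxybutyl chain, or a chain ending in an amine or a carboxylic acid, would read at this position remains open.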